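Side-chain methylation on the shared core: cytotoxicity notes

The source may report more compounds than this note shows. Statements on the series, on what has been measured and on what is new or still open speak of the compounds shown alone.

Compound 1 `COC(=O)[C@H](CO)NC(=O)c1cnc2ccccc2c1Cl` is the parent of the set. In an ADME assay on CCRF-CEM cells (Homo sapiens) for cytotoxicity (a lower number here means that less compound is tolerated, a higher number that more compound is tolerated), compound 1 gives > 100 uM, which is a limit of the assay and not a number. Compound 2 `CCOC(=O)[C@H](CO)NC(=O)c1cnc2ccccc2c1Cl` differs from compound 1 by methyl in place of hydrogen on a saturated chain carbon bound to an oxygen next to a carbonyl group. In this assay compound 2 gives > 100 uM, again a limit rather than a number. The step that the two limits leave unreadable from compound 1 to compound 2 cannot be sized, since both ends sit at the limit of > 100 uM in this assay, at which 2 of the 3 values shown sit. Compound 3 `COC(=O)[C@H](CO)NC(=O)c1cnc2cc(C)ccc2c1Cl` differs from compound 1 by methyl in place of hydrogen on an aromatic carbon. In this assay, among the measured compounds shown here, compound 3 gives 59.6 uM, the only number in the set. The step of an at least 1.6-fold lower number from compound 1 to compound 3 (0.22 log units; that floor lies within the scatter) is read against a limit.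

Compound 4 `COC(=O)[C@@H](NC(=O)c1cnc2cc(C)ccc2c1Cl)[C@@H](C)O` is not yet measured and differs from compound 3 by methyl in place of hydrogen on a saturated chain carbon bound to an oxygen on a saturated carbon and a saturated chain carbon. This is the same kind of change as from compound 1 to compound 2, though the place differs: there the saturated chain carbon is bound to an oxygen next to a carbonyl group, here to an oxygen on a saturated carbon and a saturated chain carbon. The earlier step has no readable size. The expectation therefore rests on compound 3 alone, at 59.6 uM. For compound 4 the expected step is a 1.0-fold higher number from compound 3 to compound 4 (0.00 log units; within the scatter). Compound 4 is estimated at 60 uM, expected between 25 uM and 150 uM.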

Compound 4, half-maximal toxic concentration: > 100 uM
Compound 4 gave a limit, no number (the forecaster's own chance of this, stated with the estimate: 35%); middle value at least 1.6-fold (0.22 log units) away from the limit.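

Compound 4 gives > 100 uM in this assay, which is a limit of the assay and not a number. On the core of compound 3, the new step is an at least 1.6-fold higher number from compound 3 to compound 4 (0.22 log units; that floor lies within the scatter), so hydroxymethyl to 1-hydroxyethyl is sized only by a floor, and that result does not establish a real change. The like methyl step on the core of compound 1 cannot be read, and the place of the change also differs, so the two steps cannot be compared and nothing here shows that the change carries from one core to the other, with most of the series sitting at one limit: the limit of > 100 uM in this assay, at which 3 of the 4 values shown sit.

The compounds shown leave open where compound 1, compound 2 and compound 4 would fall if read as numbers, and so whether the two cores respond alike. Also open, on these data alone, is how an amine or a longer chain at the place of the 1-hydroxyethyl group would read in this assay.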